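This account rests on a few compounds, and the source may have more. Where it says the series, first, only, none or still open, it means among the compounds named here.

Measured so far:
- compound 1 `COc1ccc(Nc2nc(-c3cccc(F)c3)nc3ccc(F)cc23)cc1` gives 41100 nM in a functional assay on U-937 cells (Homo sapiens) for cytotoxicity, read by MTT assay, with a stated time of 48 h; on this read-out higher numbers stand for weaker inhibition and lower numbers for stronger inhibition.
- compound 2 `COc1ccccc1Nc1nc(-c2cccc(F)c2)nc2ccc(F)cc12` reaches only the limit of this assay, > 50000 nM, and so has no number.
- compound 3 `Fc1cccc(Nc2nc(-c3cccc(F)c3)nc3ccc(F)cc23)c1` gives 42300 nM in this assay.

Compound 3 stands highest of the two numbers shown, with compound 1 nearest, a 1.0-fold higher number from compound 1 to compound 3 (0.01 log units; within the scatter), so the two cannot be told apart. Compound 2 sits at the limit (the limit of > 50000 nM in this assay, at which 1 of the 3 values shown sits), which gives its steps a floor only: an at least 1.2-fold higher number from compound 1 to compound 2 (0.08 log units; that floor lies within the scatter) and an at least 1.1-fold lower number from compound 2 to compound 3 (0.07 log units; that floor lies within the scatter).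

Compound 4 `Fc1cccc(-c2nc(Nc3ccccc3Cl)c3cc(F)ccc3n2)c1` differs from compound 3 in one place: 2-chlorophenyl in place of 3-fluorophenyl on a nitrogen on an aromatic ring. Within the data shown here, the steps that bear on this are the three exchanges of the aryl group on that nitrogen among compounds 1, 2 and 3, and none of them moved this assay beyond the scatter or past its floor. A similar exchange is therefore expected to leave the read-out roughly where compound 3 sits, with no step beyond the scatter in either direction, a 1.1-fold higher number from compound 3 to compound 4 (0.03 log units; within the scatter). Compound 4 is estimated at 45000 nM, between 18000 nM and 110000 nM, with a fair chance that only the limit of this assay is reported.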

Compound 4, half-maximal inhibitory concentration: > 50000 nM
Compound 4: only a limit was reported; the forecaster's own chance of this, stated with the estimate: 40%; middle value at least 1.1-fold (0.04 log units) from the limit.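

In this assay, the second group with a 2-substituted name on that nitrogen also ends at a limit: compound 2 (2-methoxyphenyl) and compound 4 (2-chlorophenyl) have no number, whereas compound 1 (4-methoxyphenyl) and compound 3 (3-fluorophenyl) do. The floors, an at least 1.1-fold higher number from compound 3 to compound 4 (0.07 log units; that floor lies within the scatter) and an at least 1.2-fold higher number from compound 1 to compound 4 (0.08 log units; that floor lies within the scatter), still show no separation from these two compounds, so this is a shared reporting outcome and not a demonstrated loss. The step between compound 2 and compound 4 cannot be read, and the series now holds a further compound without a number: the limit of > 50000 nM in this assay, at which 2 of the 4 values shown sit.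

The compounds shown leave open whether any aryl exchange at this nitrogen moves the read-out beyond the scatter. They also leave open whether an amine or a carboxylic acid on that ring, or a longer chain in place of the ring, would bring a number clearly lower than those of compound 1 and compound 3.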